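Trihydroxyphenyl to 4-hydroxyphenyl in a three-compound series

This account rests on a few compounds, and the source may have more. Where it says the series, first, only, none or still open, it means among the compounds named here.

compound 1 `O=C(CCc1nc2ccccc2c(=O)[nH]1)N/N=C/c1ccc(O)cc1`: 105000000 nM
compound 2 `O=C(CCCc1nc2ccccc2c(=O)[nH]1)N/N=C/c1cc(O)c(O)c(O)c1`: 40000000 nM
compound 3 `O=C(CCc1nc2ccccc2c(=O)[nH]1)N/N=C/c1ccc(Cl)cc1`: 185000000 nM

In a physicochemical assay, read by spectrophotometry, with a stated time of 6 min (a lower number here means a stronger inhibitor, a higher number a weaker inhibitor), compound 2 gives 40000000 nM, the lowest number of the three, and its gap to each of the others lies beyond the scatter. Compound 4 `O=C(CCCc1nc2ccccc2c(=O)[nH]1)N/N=C/c1ccc(O)cc1` is not yet measured. It keeps the chain of compound 2 and differs from it by 4-hydroxyphenyl in place of 3,4,5-trihydroxyphenyl on a carbon with a double bond to nitrogen.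

Among the compounds with values here, only one measured step changes a group on this aromatic ring: a 1.8-fold higher number from compound 1 to compound 3 (0.25 log units; within the scatter), with chloro in place of hydroxy, and it stays within the scatter. Within the data shown here, no measured step shows this exact change. Compound 1 also carries 4-hydroxyphenyl and gives 105000000 nM, but its chain differs from that of compound 2, so it is only a loose guide. A modest rise is therefore expected in this assay, towards a weaker inhibitor, as the estimated 2.0-fold higher number from compound 2 to compound 4 (0.30 log units; within the scatter). The estimated value for compound 4 is 80000000 nM, with an expected range of 35000000 nM to 170000000 nM.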

Compound 4, half-maximal inhibitory concentration: 170000000 nM
The estimate for compound 4 lay 2.1-fold (0.33 log units) below the measured number, and the stated range covers the measured number.
By their numbers in this assay, from the lowest: compound 2; then compounds 1, 4 and 3 (each within the scatter of the next).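

With the chain of compound 2 held fixed in this assay, 4-hydroxyphenyl in place of 3,4,5-trihydroxyphenyl on a carbon with a double bond to nitrogen gives a 4.3-fold higher number from compound 2 to compound 4 (0.63 log units; beyond the scatter), so this aryl change moves the number beyond the scatter and towards a weaker inhibitor, unlike the earlier ring change, a 1.8-fold higher number from compound 1 to compound 3 (0.25 log units; within the scatter). Both carrying 4-hydroxyphenyl, compound 1 at 105000000 nM and compound 4 at 170000000 nM lie within the scatter of each other, so their different chains show no readable effect with this group. No measurement here accounts for the size of the step.

On these data alone, whether all three hydroxy groups are needed remains open, and 3,4-dihydroxyphenyl or 3,4,5-trimethoxyphenyl would test this. Also open, as far as these compounds go, is whether 3,4,5-trihydroxyphenyl gives the same result on the chain of compound 1.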